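Tetrazolyl in place of hydroxymethyl on the shared core

A few compounds are considered here, and "the series" means these few. Any claim that something is new, unique, unknown or untested is made for them only; others in the source may bear on it.

Compound 1 `OCc1cc(-c2ccccc2)c2ccc(OCc3cccc(C4(O)CCOCC4)c3)cc2c1` carries a hydroxymethyl on the shared core. Within the data shown here, in a functional assay for inhibition, with Homo sapiens as the target (on this read-out higher numbers stand for weaker inhibition and lower numbers for stronger inhibition), compound 1 gives 9 nM, the highest of the three numbers measured so far. Compound 2 `CC(=O)c1cc(-c2ccccc2)c2ccc(OCc3cccc(C4(O)CCOCC4)c3)cc2c1` gives 2 nM and compound 3 `N#Cc1cc(-c2ccccc2)c2ccc(OCc3cccc(C4(O)CCOCC4)c3)cc2c1` gives 3 nM. The step of a 4.5-fold lower number from compound 1 to compound 2 (0.65 log units; beyond the scatter) and the step of a 3.0-fold lower number from compound 1 to compound 3 (0.48 log units; beyond the scatter) both lower the number; between the two replacements the step of a 1.5-fold higher number from compound 2 to compound 3 (0.18 log units; within the scatter).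

Compound 4 `OC1(c2cccc(COc3ccc4c(-c5ccccc5)cc(-c5nn[nH]n5)cc4c3)c2)CCOCC1` is not yet measured. It differs from compound 1 in one place: 2H-tetrazol-5-yl in place of hydroxymethyl on an aromatic carbon. Both measured steps that bear on it also exchange the hydroxymethyl on the same aromatic carbon, for acetyl or for cyano, and both gave a modest lower number. Among the measured compounds shown here, no measured step exchanges the hydroxymethyl for a ring, so the size expected for the tetrazolyl group is less certain than for those two. On balance a modest lower number in this assay is expected for compound 4, in the direction seen for compound 2 and compound 3. The estimate for compound 4 in this assay is 4 nM, with a range from 1.5 nM to 12 nM. This estimate means the step of a 2.3-fold lower number from compound 1 to compound 4 (0.35 log units; beyond the scatter), which is expected to lie just beyond the scatter.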

Compound 4, half-maximal inhibitory concentration: > 700 nM
Compound 4: no number, only a limit; the forecaster's own chance of this, stated with the estimate: 2%; middle value at least 170-fold (2.24 log units) from the limit.
By their numbers in this assay, from the lowest: compounds 2 and 3 (each within the scatter of the next); then compound 1. At a limit, above all of these: compound 4.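

In this assay compound 4 gives no number, only a limit: the limit of > 700 nM in this assay, at which 1 of the 4 values shown sits.

This position on the aromatic carbon, meta to a phenyl group, does not accept every replacement of the hydroxymethyl: 2H-tetrazol-5-yl gives an at least 77-fold higher number from compound 1 to compound 4 (1.89 log units; beyond the scatter), and against the two more favourable groups the steps are an at least 230-fold higher number from compound 3 to compound 4 (2.36 log units; beyond the scatter) and an at least 350-fold higher number from compound 2 to compound 4 (2.54 log units; beyond the scatter). Among these compounds, the direction is opposite to that of the acetyl and cyano replacements, so those two earlier steps, both to groups without a ring, gave no reliable guide to this ring, and the position is far more sensitive to the group placed there than the earlier compounds showed.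

The compounds shown do not separate the effect of having a five-membered aromatic ring here from the effect of this particular ring with its 4 hetero atoms, and the true size of the step stays unknown behind the limit. A carboxylic acid, an amine or an oxazolyl ring at the same carbon would show whether the large step belongs to the tetrazolyl group alone or extends to other groups.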